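The source may report more compounds than this note shows. Statements on the series, on what has been measured and on what is new or still open speak of the compounds shown alone.

Measured so far in an ADME assay on HEK293 cells (Homo sapiens) for antiproliferative activity, read by MTT assay; a higher number here means a weaker inhibitor, a lower number a stronger inhibitor:
compound 1, `CNC(=O)c1oc2nc(-c3ccccc3)cc(C(F)(F)F)c2c1N`, 62000 nM
compound 2, `Nc1c(C(=O)N/N=C/c2ccc(Cl)cc2)oc2nc(-c3cccs3)cc(C(F)(F)F)c12`, 83000 nM

Compound 2 stands at the top of the two numbers shown in this assay, yet compound 1 sits so close that the gap falls within the scatter and no order between them can be claimed. Compound 3, `Nc1c(C(=O)N/N=C/c2ccc(Cl)cc2)oc2nc(-c3ccccc3)cc(C(F)(F)F)c12`, differs from compound 2 by phenyl in place of thiophen-2-yl on an aromatic carbon. Going by the values given here, no measured pair isolates this change; compound 1 and compound 2 differ in more than one place and show only that both values are close. The step from compound 2 to compound 3 is therefore expected to stay within the scatter, a 1.2-fold lower number from compound 2 to compound 3 (0.07 log units; within the scatter). Compound 3 is estimated at 70000 nM, with a range of 30000 nM to 160000 nM.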

Compound 3, half-maximal inhibitory concentration: 81000 nM
Beside the measured number, compound 3's estimate is 1.2-fold (0.06 log units) below it, within the range that was stated.
By their numbers in this assay, from the lowest: compounds 1, 3 and 2 (each within the scatter of the next).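

In this assay phenyl in place of thiophen-2-yl on this aromatic carbon, next to the ring nitrogen, gives a 1.0-fold lower number from compound 2 to compound 3 (0.01 log units; within the scatter) and so leaves no readable difference between the two rings here. The first pair differing in one place on the amide-type nitrogen gives a 1.3-fold higher number from compound 1 to compound 3 (0.12 log units; within the scatter) for the group of 9 heavy atoms in place of one carbon atom, so that exchange also shows no readable difference. No evidence on the cause accompanies either step.

As far as these compounds go, whether an amine at this aromatic carbon, or a longer alkyl chain on the amide-type nitrogen, would move the number beyond the scatter stays open.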